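The compounds below may be only part of what the source reports. "The series", "measured", "known", "first", "only" and "open" are said of these compounds alone.

Measured so far in a physicochemical assay for solubility, with a stated time of 18 h, at pH 7.4; on this read-out higher numbers stand for higher solubility and lower numbers for lower solubility:
compound 1 `COc1cccc(CNCCCNc2ccnc3cc(-c4ccc(C(F)(F)F)cc4)ccc23)c1O` gives 32000 nM;
compound 2 `FC(F)(F)c1ccc(-c2ccc3c(NCCCNCc4ccco4)ccnc3c2)cc1` gives 32000 nM;
compound 3 `COc1ccc(F)cc1CNCCCNc1ccnc2cc(-c3ccc(C(F)(F)F)cc3)ccc12` gives 32000 nM.

Compound 1 stands level with compounds 2 and 3 in this assay: the steps of no change at the digits printed from compound 1 to compound 2 (within the scatter) and no change at the digits printed from compound 1 to compound 3 (within the scatter) both lie within the scatter, as does no change at the digits printed from compound 2 to compound 3 (within the scatter). Those three steps all change the group on the saturated chain carbon bound to an amine nitrogen.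

Compound 4 `COc1cccc(CNCCCNc2ccnc3cc(CCc4ccccc4)ccc23)c1O` differs from compound 1 elsewhere: phenethyl in place of 4-(trifluoromethyl)phenyl on an aromatic carbon. Within the data shown here, no measured step touches that part of the shared core, so none bears directly on it. In the absence of such a step, compound 4 is expected to stay within the scatter of compound 1, a step of no change at the digits printed from compound 1 to compound 4 (within the scatter). Compound 4 is thus estimated at 32000 nM, within 16000 nM to 64000 nM.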

Compound 4, solubility: 4200 nM
Estimate against measurement, compound 4: 7.6-fold (0.88 log units) above; the whole stated range lies above it.
By their numbers in this assay, from the lowest: compound 4; then compounds 1, 2 and 3 (each within the scatter of the next).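

Unlike the changes on the chain carbon, which all stayed within the scatter, a change at this aromatic carbon of the shared core moves this assay: phenethyl in place of 4-(trifluoromethyl)phenyl gives a 7.6-fold lower number from compound 1 to compound 4 (0.88 log units; beyond the scatter), beyond the scatter. This position therefore matters for this read-out, at least for this one change. Nothing available explains the step.

The compounds shown cannot say whether the step follows from losing the trifluoromethyl group or from gaining the chain of phenethyl. A plain phenyl or a benzyl group at this carbon would help separate the two.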